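Swapping the sulfonyl aryl group in a chloro-cored series

The source may report more compounds than this note shows. Statements on the series, on what has been measured and on what is new or still open speak of the compounds shown alone.

Measured compounds: compound 1 `COc1ccc2ncc(S(=O)(=O)c3ccc(C)c(Cl)c3)c(N3CCC(C)CC3)c2c1` gives 85%; compound 2 `Cc1ccc(S(=O)(=O)c2cnc3cc(Cl)ccc3c2N2CCC(C)CC2)cc1F` gives 85%; compound 3 `COc1ccc2ncc(S(=O)(=O)c3ccc(Cl)cc3)c(N3CCC(C)CC3)c2c1` gives 91%, all in an assay on isolated protein for displacement of a labelled ligand from metabotropic glutamate receptor 5 (Homo sapiens), with a stated time of 60 min, tested at 1 uM; a higher number here means more inhibition at the concentration tested (going by the name of the read-out), a lower number less inhibition.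

Compound 2 stands level with compound 1 at the digits shown, the two together being the lowest of the three numbers, and compound 3 sits a little higher, though within the scatter. Compound 4 `CC1CCN(c2c(S(=O)(=O)c3cccc(Cl)c3)cnc3cc(Cl)ccc23)CC1` has not yet been measured. It differs from compound 2 in one place: 3-chlorophenyl in place of 3-fluoro-4-methylphenyl on a sulfonyl sulfur

Within the data shown here, the only measured step of the same kind, a change of the aryl group on the sulfonyl sulfur, is a number 6 percentage points higher from compound 1 to compound 3 (within the scatter), which lies within the scatter. On that basis no step beyond the scatter is expected in this assay for compound 4, whose expected step is no change at the digits printed from compound 2 to compound 4 (within the scatter). Compound 4 is therefore estimated at 85%, with a range of 70% to 95%.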

Compound 4, a percentage reported as inhibition, at one concentration (the size of the read-out at that concentration, not a potency): 92%
For compound 4 the middle estimate is 7 percentage points below the measured one; low and high end bracket the measured number.
By their numbers in this assay, from the lowest: compounds 1, 2, 3 and 4 (each within the scatter of the next).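

In this assay, the change gives a number 7 percentage points higher from compound 2 to compound 4 (within the scatter). The earlier step on the sulfonyl sulfur came from compounds with a different core, so this shows that a second core also accepts a swap of aryl group there with no step beyond the scatter: 3-chlorophenyl stands in for 3-fluoro-4-methylphenyl. No measurement here offers an explanation for this result.

Every group shown on the sulfonyl sulfur is a phenyl ring carrying chlorine, fluorine or methyl. On these data alone, how a pyridine ring, or a phenyl ring bearing an amine or a carboxylic acid, would behave there remains open.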